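Moving From Cyclohexylamino to a Chlorophenyl Ketone on the Chain

The source may hold more compounds than are shown below. What is called first, only, known or untested is meant among the compounds shown, and "the series" means these compounds.

Three compounds share a core and differ only in the group on the amide carbonyl. Compound 1 `Cc1cc(CC(C)C(=O)N2CCN(c3ccc(C(F)(F)F)cc3[C@@H](N)CC(C)C)CC2)ccc1Cl` gives 71 nM in an assay on HEK293 cells for displacement of a labelled ligand from Melanocortin receptor 4 (Homo sapiens); on this read-out higher numbers stand for weaker inhibition and lower numbers for stronger inhibition. Compound 2 `CC(C)C[C@H](N)c1cc(C(F)(F)F)ccc1N1CCN(C(=O)CCC(N)=O)CC1` reaches only the limit of > 10000 nM in this assay (the limit of > 10000 nM in this assay, at which 1 of the 3 values shown sits). Compound 3 `CC(C)C[C@H](N)c1cc(C(F)(F)F)ccc1N1CCN(C(=O)CCNC2CCCCC2)CC1` gives 4800 nM in this assay, the highest number among those measured, with compound 1 the nearest at a 68-fold higher number from compound 1 to compound 3 (1.83 log units; beyond the scatter). The step of an at least 2.0-fold lower number from compound 2 to compound 3 (0.31 log units; beyond the scatter) shows that replacing carbamoyl with cyclohexylamino brought at least a modest gain.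

Compound 4 `CC(C)C[C@H](N)c1cc(C(F)(F)F)ccc1N1CCN(C(=O)CCC(=O)c2ccc(Cl)cc2)CC1` carries (4-chlorophenyl)carbonyl in place of cyclohexylamino on a saturated chain carbon, two bonds along the chain from a carbonyl carbon. The relevant measured steps are the large one an at least 140-fold higher number from compound 1 to compound 2 (2.14 log units; beyond the scatter) and the large one a 68-fold higher number from compound 1 to compound 3 (1.83 log units; beyond the scatter), both of which show that substituents on this chain with a chlorinated aromatic ring, as in compound 1, are associated with far lower numbers, while the small polar or saturated groups of compounds 2 and 3 are not. The (4-chlorophenyl)carbonyl group brings such a ring back, so a lower number is expected, though the chain differs from that of compound 1; the expected step is a 4.8-fold lower number from compound 3 to compound 4 (0.68 log units; beyond the scatter). Compound 4 is therefore estimated at 1000 nM, within 200 nM to 5000 nM.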

Compound 4, inhibition constant: 820 nM
For compound 4 the middle estimate is 1.2-fold (0.09 log units) above the measured one, and the stated range covers the measured number.
By their numbers in this assay, from the lowest: compound 1; then compound 4; then compound 3. At a limit, above all of these: compound 2.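

Putting (4-chlorophenyl)carbonyl in place of cyclohexylamino gives a 5.9-fold lower number from compound 3 to compound 4 (0.77 log units; beyond the scatter) and shows that a chlorinated aromatic ring on a chain without the branch of compound 1 still lowers the number, while 4-chlorophenyl in place of amino on a carbonyl carbon gives an at least 12-fold lower number from compound 2 to compound 4 (1.08 log units; beyond the scatter) as a second step in the same direction. That second step is bounded on one side only, as compound 2 stands at a limit: the limit of > 10000 nM in this assay, at which 1 of the 4 values shown sits. The ring alone does not recover what compound 1 shows, for the change of chain leaves a 12-fold higher number from compound 1 to compound 4 (1.06 log units; beyond the scatter) as a remaining gap.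

The compounds shown leave open how much of the gain belongs to the chlorine and how much to the ketone carbonyl. A plain phenyl ketone, a secondary alcohol in place of the ketone or a longer chain would separate these parts.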